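Hexyloxy on the Aromatic Ring of Compound 1

This account rests on a few compounds, and the source may have more. Where it says the series, first, only, none or still open, it means among the compounds named here.

Compound 1 `Cc1[nH]c(=O)n(C)c1-c1ccccc1` is the unsubstituted parent of this small set. In a functional assay on brain (Rattus norvegicus, strain Wistar) for inhibition (on this read-out lower numbers stand for stronger inhibition and higher numbers for weaker inhibition), compound 1 gives only a limit, > 100000 nM. It therefore stands at the weak end of the measured values, at the limit of > 100000 nM in this assay, at which 1 of the 3 values shown sits. The change to compound 4 `CCCCCCOc1ccc(-c2c(C)[nH]c(=O)n2C)cc1` is hexyloxy in place of hydrogen on an aromatic carbon. For the measured compounds named here, two measured steps bear on it. Compound 2 `Cc1[nH]c(=O)n(C)c1-c1ccc(CC(C)C)cc1` carries isobutyl at the same place and gives 7800 nM in this assay, a step of an at least 12-fold lower number from compound 1 to compound 2 (1.10 log units; beyond the scatter). Compound 3 `CCCCCc1ccc(-c2c(C)[nH]c(=O)n2C)cc1` carries pentyl there and gives 5900 nM, a step of an at least 16-fold lower number from compound 1 to compound 3 (1.22 log units; beyond the scatter), while the chains differ by only a 1.3-fold lower number from compound 2 to compound 3 (0.12 log units; within the scatter). For compound 4 a similarly large downward step is expected, an at least 22-fold lower number from compound 1 to compound 4 (1.34 log units; beyond the scatter). Compound 4 is estimated at 4500 nM, between 1000 nM and 20000 nM.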

Compound 4, half-maximal inhibitory concentration: 7300 nM
The estimate for compound 4 lay 1.6-fold (0.21 log units) below the measured number, and the stated range covers the measured number.
By their numbers in this assay, from the lowest: compounds 3, 4 and 2 (each within the scatter of the next). At a limit, above all of these: compound 1.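

In this assay, hexyloxy, the first chain here that carries an oxygen, also gives a large step on this aromatic carbon, with an at least 13-fold lower number from compound 1 to compound 4 (1.13 log units; beyond the scatter). Its effect cannot be told apart from that of the plain carbon chains, with a 1.2-fold higher number from compound 3 to compound 4 (0.09 log units; within the scatter) and a 1.1-fold lower number from compound 2 to compound 4 (0.03 log units; within the scatter), so among these three groups the oxygen brings no difference that can be read. The value of compound 1 is a limit: the limit of > 100000 nM in this assay, at which 1 of the 4 values shown sits.

As far as these compounds go, whether a methoxy group, an amine or a carboxylic acid on this aromatic carbon would give a step of similar size remains open.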